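Carbamoyl to methoxycarbonyl: how long will compound 3 last?

This account rests on a few compounds, and the source may have more. Where it says the series, first, only, none or still open, it means among the compounds named here.

Compound 1 `CCCC(CCC)C(=O)N(C)/N=N/c1ccc(C(=O)OCC)cc1` gives 34.1 h
Compound 2 `CCCC(CCC)C(=O)N(C)/N=N/c1ccc(C(N)=O)cc1` gives > 40 h (a limit)
Compound 3 `CCCC(CCC)C(=O)N(C)/N=N/c1ccc(C(=O)OC)cc1` is not yet measured

In a physicochemical assay for pharmacokinetics, read by HPLC, in phosphate buffer, at pH 7.4 (a higher number here means that the compound lasts longer, a lower number that the compound disappears faster), compound 2 stands at > 40 h, which is a limit and not a number. Compound 3 puts methoxy in place of amino on a carbonyl carbon. Within the data shown here, the one measured step that bears on this is an at least 1.1-fold higher number from compound 1 to compound 2 (0.06 log units; that floor lies within the scatter), which put amino in place of ethoxy and stays within the scatter. Reversing that kind of swap, no step beyond the scatter is expected in this assay. The expected step is an at least 1.1-fold lower number from compound 2 to compound 3 (0.07 log units; that floor lies within the scatter). For compound 3 the estimate is 34 h, with an expected range of 20 h to 55 h.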

Compound 3, half-life: 31.4 h
Compound 3: middle estimate off by 1.1-fold (0.03 log units), on the high side; the range from low to high includes it.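

With ethoxy or methoxy on the carbonyl carbon, the half-lives cannot be told apart in this assay: a 1.1-fold lower number from compound 1 to compound 3 (0.04 log units; within the scatter). Putting methoxy in place of amino gives only a floor for the step, and that floor does not clear the scatter: an at least 1.2-fold lower number from compound 2 to compound 3 (0.10 log units; that floor lies within the scatter). Compound 2 is held at a limit and not a number: the limit of > 40 h in this assay, at which 1 of the 3 values shown sits.

On these data alone, how far compound 2 lies past its limit stays open. So does how long the compound would last in this assay with a hydroxyl, making a carboxylic acid, or a dimethylamino group on this carbonyl carbon.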